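From Benzyl to Phenyl on a Shared Core

The source may report more compounds than this note shows. Statements on the series, on what has been measured and on what is new or still open speak of the compounds shown alone.

In a functional assay on V79-379A cells (Cricetulus griseus) for cytotoxicity, read by MTT assay, in the presence of a further agent that is not named here (a higher number here means a weaker inhibitor, a lower number a stronger inhibitor), compound 1 (`COC1=CC(=O)c2c(c(COC(=O)c3ccccc3)cn2C)C1=O`) gives 1400 nM and compound 2 (`COC1=CC(=O)c2c(c(COCc3ccccc3)c(C)n2C)C1=O`) gives 225000 nM as the higher of the two numbers, with a gap beyond the scatter. These two compounds differ in more than one place, so their gap cannot be traced to any single change. Compound 3 (`COC1=CC(=O)c2c(c(COc3ccccc3)c(C)n2C)C1=O`) departs from compound 2 in one place only: phenyl in place of benzyl on an oxygen on a saturated carbon. Among the measured compounds shown here, no measured pair differing in one place is available to size this change, so any expectation for it remains a judgement. With compound 2 at 225000 nM and compound 1 at 1400 nM the measured numbers leave more room downward than upward from compound 2. The expected change is a 7.5-fold lower number from compound 2 to compound 3 (0.88 log units; beyond the scatter) in this assay as a moderate step toward a lower number, beyond the scatter. For compound 3 the expected value is 30000 nM with a range of 4000 nM to 200000 nM around that estimate.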

Compound 3, half-maximal inhibitory concentration: 12000 nM
Compound 3: the middle estimate sits 2.5-fold (0.40 log units) above what was measured; low and high end bracket the measured number.
By their numbers in this assay, from the lowest: compound 1; then compound 3; then compound 2.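

Within this assay, a change in this place now has a measured size: phenyl in place of benzyl on an oxygen on a saturated carbon gives a 19-fold lower number from compound 2 to compound 3 (1.27 log units; beyond the scatter) and is the only step here that can be tied to one change. With the rest of the molecule held constant, this position responds beyond the scatter to a small change, from 7 heavy atoms to 6, while the aromatic ring, the absence of hydrogen-bond donors and acceptors and the lack of net charge stay the same. Nothing measured here bears on why the step has this size.

The compounds shown leave open how far this response extends, including whether a phenyl ring carrying a carboxylic acid or an amine, or a longer chain such as phenethyl on the same oxygen, would move the number in the same direction. They also leave open whether benzyl to phenyl would give a step of similar size on the core of compound 1, which differs from compound 2 in more than one place.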